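Three inactive triazole ethers and a 2-fluorophenyl analogue

A few compounds are considered here, and "the series" means these few. Any claim that something is new, unique, unknown or untested is made for them only; others in the source may bear on it.

Compound 1, `O=c1ccoc2cc(OCc3cn(Cc4ccc([N+](=O)[O-])cc4)nn3)ccc12`, gives > 100000 nM in a functional assay on A549 cells (Homo sapiens) for cytotoxicity, read by MTT assay, with a stated time of 48 h (a lower number here means a stronger inhibitor, a higher number a weaker inhibitor), and that reading is a limit of the assay rather than a number.
Compound 2, `O=c1ccoc2cc(OCc3cn(Cc4cccc(Br)c4)nn3)ccc12`, gives > 100000 nM in this assay, again a limit.
Compound 3, `O=c1ccoc2cc(OCc3cn(Cc4ccc(F)cc4)nn3)ccc12`, gives > 100000 nM in this assay, likewise a limit.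

Compound 1 therefore stands at the limit, with no measurable inhibition shown, and the same holds for the two other compounds, as summarised by the limit of > 100000 nM in this assay, at which 3 of the 3 values shown sit. Compound 4, `O=c1ccoc2cc(OCc3cn(Cc4ccccc4F)nn3)ccc12`, has not yet been measured. It differs from compound 1 by 2-fluorophenyl in place of 4-nitrophenyl on a saturated chain carbon bound to an aromatic nitrogen.

Going by the values given here, the steps that bear on this change are a step that the two limits leave unreadable from compound 1 to compound 2, a step that the two limits leave unreadable from compound 1 to compound 3 and a step that the two limits leave unreadable from compound 2 to compound 3. Among the compounds with values here, each of them joins two limits, so none of them can be read in size or direction; they show only that exchanging the group on the saturated chain carbon bound to the aromatic nitrogen among the 4-nitrophenyl, 3-bromophenyl and 4-fluorophenyl variants left every compound at the limit. Placing a 2-fluorophenyl there is a change of the same kind. Compound 4 is accordingly expected to remain at the limit, so that the step that the limit leaves unreadable from compound 1 to compound 4 is expected to be unreadable. The estimate for compound 4 is 150000 nM, with a range from 60000 nM to 500000 nM.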

Compound 4, half-maximal inhibitory concentration: 10800 nM
Compound 4: the middle estimate sits 14-fold (1.14 log units) above what was measured; the whole stated range lies above it.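

Going by these compounds alone, the 2-fluorophenyl group on the saturated chain carbon bound to an aromatic nitrogen gives the first reading in this assay that is a number and not a limit, and replacing 4-nitrophenyl with it gives an at least 9.2-fold lower number from compound 1 to compound 4 (0.96 log units; beyond the scatter). Moving from 4-fluorophenyl to 2-fluorophenyl gives an at least 9.2-fold lower number from compound 3 to compound 4 (0.96 log units; beyond the scatter) and replacing 3-bromophenyl gives an at least 9.2-fold lower number from compound 2 to compound 4 (0.96 log units; beyond the scatter), so a fluoro substituent on the phenyl ring is not enough for a reading, and this place responds to which substituted phenyl it carries. Compound 4 is the only compound shown to leave the limit, while the steps among compound 1, compound 2 and compound 3 still cannot be read: the limit of > 100000 nM in this assay, at which 3 of the 4 values shown sit.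

Going by these compounds, each step from a limit gives only a minimum, so the full size of the gain for compound 4 stays open. On these data alone, it is also open whether the reading is specific to 2-fluorophenyl or would persist with 2-chlorophenyl, 2-methoxyphenyl or unsubstituted phenyl, or with a longer chain carrying the ring.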